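The source may hold more compounds than are shown below. What is called first, only, known or untested is meant among the compounds shown, and "the series" means these compounds.

Measured compounds:
compound 1 `Cc1cccc(/C(N)=N/NC(=S)N2CCCCC2)n1` gives 2000 nM in a functional assay on HeLa cells (Homo sapiens) for cytotoxicity, read by MTT assay, with a stated time of 72 h; a higher number here means a weaker inhibitor, a lower number a stronger inhibitor
compound 2 `Cc1cccc(/C(N)=N/NC(=S)N2CCCC2)n1` gives 2700 nM in this assay
compound 3 `Cc1ccnc(/C(N)=N/NC(=S)N2CCCCC2)c1` gives 7700 nM in this assay

Compound 1 and compound 2 share a core and differ in one place: pyrrolidin-1-yl in place of piperidin-1-yl on a thiocarbonyl carbon. The step that goes with this change is a 1.4-fold higher number from compound 1 to compound 2 (0.13 log units; within the scatter), so the two values cannot be told apart by this assay.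

Compound 3 is built from the same atoms as compound 1, joined differently; the difference between the two cores is not broken down here. Compound 3 gives the highest number of the three, and its values against compound 2 and compound 1 both lie beyond the scatter, so it reads as the weaker inhibitor of the set.

Compound 4 `Cc1ccnc(/C(N)=N/NC(=S)N2CCCC2)c1` has not been measured. Against compound 3 it carries pyrrolidin-1-yl in place of piperidin-1-yl on a thiocarbonyl carbon, which is the same change as that from compound 1 to compound 2, at the same place on the same kind of neighbour. For the measured compounds named here, the one measured instance of this change gave a 1.4-fold higher number from compound 1 to compound 2 (0.13 log units; within the scatter), a step within the scatter; on that basis the step from compound 3 to compound 4 is expected to be small as well, about a 1.3-fold higher number from compound 3 to compound 4 (0.11 log units; within the scatter). Compound 4 is therefore estimated at 10000 nM in this assay, with a likely range from 5000 nM to 22000 nM, because compound 3 sits at 7700 nM and the change has so far moved the number little.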

Compound 4, half-maximal inhibitory concentration: 1900 nM
Estimate against measurement, compound 4: 5.3-fold (0.72 log units) above; the measured number lies below the stated range.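

In this assay, pyrrolidin-1-yl in place of piperidin-1-yl on a thiocarbonyl carbon gives a 4.1-fold lower number from compound 3 to compound 4 (0.61 log units; beyond the scatter) and this step lies beyond the scatter, whereas the same change left compound 1 and compound 2 indistinguishable. The size of the effect of this change therefore does not carry over unaltered from the core of compound 1 to the core of compound 3, as the two steps set side by side show: the same change on two cores in this assay, a 1.4-fold higher number (0.13 log units; within the scatter) from compound 1 to compound 2 and a 4.1-fold lower number (0.61 log units; beyond the scatter) from compound 3 to compound 4, 5.5-fold (0.74 log units) apart, beyond the scatter of two such steps. For the compounds shown here, this rests on only two matched pairs, so it shows that the outcome of the change depends on the core in these two cases, but it does not show which difference between the two cores is responsible, and it gives no rule for predicting the step on any further core.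

The compounds shown leave open how other groups on the thiocarbonyl carbon, such as morpholin-4-yl, azepan-1-yl or dimethylamino, would behave on either core. Also open, on these data alone, is whether a third core would follow the pair compound 1 and compound 2 or the pair compound 3 and compound 4 when piperidin-1-yl gives way to pyrrolidin-1-yl.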